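Permeability notes: phenyl in place of 4-methoxyphenoxy

The source may hold more compounds than are shown below. What is called first, only, known or untested is meant among the compounds shown, and "the series" means these compounds.

Two compounds of the series have numbers in an ADME assay for permeability, using PAMPA, with a stated time of 30 min, at pH 7.4; on this read-out higher numbers stand for higher permeability and lower numbers for lower permeability. Compound 1 `COc1cccc(CNCCCNc2ccnc3cc(C4CCCCC4)ccc23)c1O` gives 23 10^-6 cm/s in this assay. Among the compounds with values here, compound 2 `COc1ccc(Oc2ccc3c(NCCCNCc4cccc(OC)c4O)ccnc3c2)cc1` gives 317 10^-6 cm/s in this assay, the higher of the two numbers; the only step to it is a 14-fold higher number from compound 1 to compound 2 (1.14 log units; beyond the scatter), and nothing else is close to it.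

Compound 3 `COc1cccc(CNCCCNc2ccnc3cc(-c4ccccc4)ccc23)c1O` is not yet measured. It differs from compound 2 in one place: phenyl in place of 4-methoxyphenoxy on an aromatic carbon. Within the data shown here, the one measured step that bears on this change is a 14-fold higher number from compound 1 to compound 2 (1.14 log units; beyond the scatter), where the 4-methoxyphenoxy group entered at the same position and the number rose strongly. Among the measured compounds shown here, removing that group again, now for phenyl rather than cyclohexyl, is expected to move the number back down, though no measured pair shows phenyl against 4-methoxyphenoxy or phenyl against cyclohexyl directly, so the size is uncertain. The step expected in this assay is a 5.3-fold lower number from compound 2 to compound 3 (0.72 log units; beyond the scatter), a decrease beyond the scatter. The estimate for compound 3 is therefore 60 10^-6 cm/s, with a range from 20 10^-6 cm/s to 200 10^-6 cm/s.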

Compound 3, apparent permeability: 237 10^-6 cm/s
Compound 3: the middle estimate sits 4.0-fold (0.60 log units) below what was measured; measured number above the stated range.
By their numbers in this assay, from the lowest: compound 1; then compounds 3 and 2 (each within the scatter of the next).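

In this assay there is a 1.3-fold lower number from compound 2 to compound 3 (0.13 log units; within the scatter) so the number does not depend on the whole 4-methoxyphenoxy group: phenyl, with 0 hydrogen-bond acceptors against 2 and fewer heavy atoms, holds the read-out within the scatter of compound 2. The other new pair shows a 10-fold higher number from compound 1 to compound 3 (1.01 log units; beyond the scatter) which gives this position a second large step, now without the 4-methoxyphenoxy group. Among these three compounds, the two with a six-membered aromatic ring of carbon only on this aromatic carbon stand together and the cyclohexyl compound stands apart, although nothing available explains that separation.

The compounds shown leave open how an amine or a carboxylic acid on this aromatic carbon would read, and whether a small group such as methyl or chlorine would stay with the aromatic pair or fall toward compound 1. Also open, on these data alone, is whether the step from cyclohexyl to phenyl keeps its size with a longer chain in the linker shared by all three compounds.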